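A few compounds are considered here, and "the series" means these few. Any claim that something is new, unique, unknown or untested is made for them only; others in the source may bear on it.

Three related chalcones have been tested in a functional assay on B16-F10 cells (Mus musculus) for antiproliferative activity, read by MTT assay, with a stated time of 48 h; a higher number here means a weaker inhibitor, a lower number a stronger inhibitor. Compound 1 `CCOc1ccc(C(=O)/C=C/c2c(/C=C/c3ccc(OC)cc3)cc(OC)cc2OC)cc1` gives 6.4 ug/mL. Compound 2 `COc1ccc(/C=C/c2cc(OC)cc(OC)c2/C=C/C(=O)c2ccccc2)cc1`, which carries a plain benzoyl group, gives 3.7 ug/mL. Compound 3 `COc1ccc(/C=C/c2cc(OC)cc(OC)c2/C=C/C(=O)c2cccc(OC)c2)cc1` gives 4.3 ug/mL. Compound 2 has the smallest of the three numbers, but the spread is narrow: the step of a 1.7-fold lower number from compound 1 to compound 2 (0.24 log units; within the scatter) and the step of a 1.2-fold higher number from compound 2 to compound 3 (0.07 log units; within the scatter) both stay within the usual scatter, so none of the three can be called the stronger inhibitor on this evidence.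

Compound 4 `COc1ccc(/C=C/c2cc(OC)cc(OC)c2/C=C/C(=O)c2ccc(Cl)cc2)cc1` differs from compound 2 in one place: chloro in place of hydrogen on an aromatic carbon. For the measured compounds named here, the step that bears most directly on this is the one from compound 2 to compound 3, where a substituent enters the same benzoyl ring and the number barely moves, a 1.2-fold higher number from compound 2 to compound 3 (0.07 log units; within the scatter). The step from compound 1 to compound 2, where a group on that ring is removed, is likewise small, a 1.7-fold lower number from compound 1 to compound 2 (0.24 log units; within the scatter). Substituents on the benzoyl ring have therefore not shifted the read-out beyond the scatter so far, and the expectation for chloro is the same: a step of a 1.1-fold lower number from compound 2 to compound 4 (0.02 log units; within the scatter) that is within the scatter. Compound 4 is accordingly expected to give about 3.5 ug/mL, within a range from 1.8 ug/mL to 7 ug/mL.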

Compound 4, half-maximal inhibitory concentration: 4.9 ug/mL
Estimate against measurement, compound 4: 1.4-fold (0.15 log units) below; measured number inside the range.
By their numbers in this assay, from the lowest: compounds 2, 3, 4 and 1 (each within the scatter of the next).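

The chloro group gives this aromatic carbon, para to a large group, a third occupant beside hydrogen and ethoxy, and a single atom in that place leaves the read-out in this assay within the scatter of both (a 1.3-fold higher number from compound 2 to compound 4 (0.12 log units; within the scatter); a 1.3-fold lower number from compound 1 to compound 4 (0.12 log units; within the scatter)). Changing the whole group on the carbonyl carbon, from 3-methoxyphenyl to 4-chlorophenyl, also stays within the scatter (a 1.1-fold higher number from compound 3 to compound 4 (0.06 log units; within the scatter)), so these compounds show no sign that the read-out depends on which of these groups the ring carries or where on the ring the group sits. Nothing available explains why these changes leave the number so little moved.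

Whether any group at this carbon can move the number beyond the scatter remains open, since an amine, a carboxylic acid or a longer chain such as hexyloxy is absent from the compounds shown. Going by these compounds, it is also open whether chloro on another carbon of the same ring would behave as it does here.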